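The source may report more compounds than this note shows. Statements on the series, on what has been measured and on what is new or still open speak of the compounds shown alone.

Four compounds on a shared core were examined in a functional assay on L1210 cells (Mus musculus) for antiproliferative activity; on this read-out higher numbers stand for weaker inhibition and lower numbers for stronger inhibition. Compound 1 `CSc1nc2c(C)nsc2n1[C@H]1C[C@H](O)[C@@H](CO)O1` and compound 2 `CSc1nc2cnsc2n1[C@H]1C[C@H](O)[C@@H](CO)O1` differ only by hydrogen in place of methyl on an aromatic carbon, while compound 3 `CSc1nc2c(C)nsc2n1[C@@H]1O[C@H](CO)[C@@H](O)[C@@H]1O` carries hydroxy in place of hydrogen on a saturated ring carbon relative to compound 1. In this assay compound 1 gives only a limit, > 100000 nM. Compound 2 likewise gives only a limit, > 100000 nM. Compound 3 also gives only a limit, > 100000 nM, so it stands on the same footing as the other two and cannot be ranked against them. The steps a step that the two limits leave unreadable from compound 1 to compound 2 and a step that the two limits leave unreadable from compound 1 to compound 3 are of unreadable size because of the limit of > 100000 nM in this assay, at which 3 of the 3 values shown sit. Compound 4 `CSc1nc2cnsc2n1[C@@H]1O[C@H](CO)[C@@H](O)[C@@H]1O` differs from compound 3 by hydrogen in place of methyl on an aromatic carbon. Going by the values given here, the only measured step of the same kind, that from compound 1 to compound 2, is itself unreadable, so neither direction nor size can be drawn from it for the change to compound 4. Compound 4 is therefore expected to give only a limit as well, and its value is estimated at 200000 nM, between 50000 nM and 1000000 nM, meaning an expected step that the limit leaves unreadable from compound 3 to compound 4.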

Compound 4, half-maximal inhibitory concentration: > 100000 nM
Compound 4: no number, only a limit; the forecaster's own chance of this, stated with the estimate: 90%; the middle value does not contradict the limit.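

Compound 4 also gives only a limit, > 100000 nM. Neither the step from compound 3 to compound 4 nor that from compound 2 to compound 4 can be read, because all four results stop at the same point: the limit of > 100000 nM in this assay, at which 4 of the 4 values shown sit. The compounds shown leave open whether either change, hydrogen in place of methyl or hydroxy in place of hydrogen, has any effect in this assay.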